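The source may hold more compounds than are shown below. What is called first, only, known or untested is meant among the compounds shown, and "the series" means these compounds.

Measured so far:
- compound 1, `COc1cc(OC)c(C(=O)/C=C/c2ccccc2SC)c(OC)c1`, 48% in a functional assay on MDA-MB-231 cells (Homo sapiens), read by fluorescence and BrdU incorporation, with a stated time of 48 h, tested at 10 uM; on this read-out higher numbers stand for a weaker effect at the one concentration tested and lower numbers for a stronger effect
- compound 2, `COc1cc(OC)c(C(=O)/C=C/c2ccccc2)c(OC)c1`, 37% in this assay
- compound 3, `COc1cc(O)c(C(=O)/C=C/c2ccccc2OC)c(OC)c1`, reported as "not active" (no number reported) in this assay

Compound 3 has no single number in this assay; it was simply reported as not active, which places it at the weak end of the three compounds measured. Compound 4, `COc1cc(O)c(C(=O)/C=C/c2ccccc2SC)c(OC)c1`, has not yet been measured. It differs from compound 3 in one place: methylsulfanyl in place of methoxy on an aromatic carbon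

For the measured compounds named here, only one measured step is available, a number 11 percentage points lower from compound 1 to compound 2 (beyond the scatter). That step concerns the methylsulfanyl group, but it pairs it with hydrogen rather than with methoxy, and it takes place on a core that carries three methoxy groups where compound 3 and compound 4 carry a hydroxyl. Going by the values given here, no measured pair shows methylsulfanyl against methoxy directly. The modest size of that step, together with the inactivity of compound 3, gives no reason to expect a move beyond the scatter in this assay.

Compound 4 is therefore expected to remain weak, with an estimated value of 85%, within a range from 60% to 100%.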

Compound 4, a percentage reported as activity, at one concentration (the size of the read-out at that concentration, not a potency): "not active" (no number reported)
Compound 4 has no reported number here, so the estimate cannot be set against anything.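

In this assay, for the compounds shown here, compound 3 and compound 4 are both reported only as not active, without a number, so no step between them can be read. On these data alone, whether methylsulfanyl in place of methoxy changes the read-out on their shared core stays open. No further evidence bears on this result.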